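The source may hold more compounds than are shown below. What is called first, only, known or untested is meant among the compounds shown, and "the series" means these compounds.

Measured so far in a functional assay on K562 cells (Homo sapiens) for antiproliferative activity, read by MTT assay, with a stated time of 48 h; on this read-out higher numbers stand for weaker inhibition of growth and lower numbers for stronger inhibition of growth:
Compound 1 `COc1ccc(N(C)c2ncnc3c2ncn3C)cc1`: > 100000 nM, a limit
Compound 2 `COc1ccc(Cn2cnc3c(N(C)c4ccc(OC)cc4)ncnc32)cc1`: > 100000 nM, a limit

Neither entry is a true number, so compound 2 has no exact place on the scale. It stands at the limit of > 100000 nM in this assay, at which 2 of the 2 values shown sit.

Compound 3 `COc1ccc(N(C)c2ncnc3c2ncn3Cc2ccc(OC)c(OC)c2)cc1` has not yet been measured. Its structure differs from that of compound 2 by methoxy in place of hydrogen on an aromatic carbon. In words, this is methoxy in place of hydrogen on an aromatic carbon, which turns 4-methoxyphenyl into 3,4-dimethoxyphenyl.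

Among the measured compounds shown here, only one measured step bears on this change: a step that the two limits leave unreadable from compound 1 to compound 2. That step also alters a 4-methoxyphenyl-bearing part of the molecule, but it offers no size or direction to carry forward. No step beyond the usual scatter is therefore expected in this assay, and compound 3 will probably be reported as a limit too. This expectation rests on compound 2, whose > 100000 nM is a limit.

The estimated change is a number no higher from compound 2 to compound 3 (the limit leaves the size open).

For compound 3 the expected value is about 100000 nM, with an estimated range from 30000 nM to 200000 nM.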

Compound 3, concentration for 50% growth inhibition: > 100000 nM
Compound 3: only a limit was reported; the forecaster's own chance of this, stated with the estimate: 75%; the middle value sits exactly at the limit.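

In this assay compound 3 gives > 100000 nM, which is a limit and not a true number. No step between compound 1, compound 2 and compound 3 can therefore be read, and all three stand at the same place: the limit of > 100000 nM in this assay, at which 3 of the 3 values shown sit.

The compounds shown leave open how strongly each inhibits growth, and whether the added methoxy changes that at all.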